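Expected Cytotoxicity of Compound 3 Next to Compound 2

A few compounds are considered here, and "the series" means these few. Any claim that something is new, unique, unknown or untested is made for them only; others in the source may bear on it.

Two compounds have so far been run through an ADME assay on L929 cells (Mus musculus) for cytotoxicity, read by resazurin assay, with a stated time of 72 h; on this read-out higher numbers stand for weaker inhibition and lower numbers for stronger inhibition. Compound 1, `OB1OCc2ccc(-n3cc(Sc4ccc(O)cc4)c4ccccc43)cc21`, gives > 10 ug/mL, which is a limit of the assay rather than a number. Compound 2, `O=C(c1ccn(-c2ccc3c(c2)B(O)OC3)c1)c1ccccc1Cl`, gives > 10 ug/mL, again a limit of the assay and not a number.

Compound 2 therefore sits at the limit of > 10 ug/mL in this assay, at which 2 of the 2 values shown sit. Among the measured compounds shown here, no step between measured compounds has been worked out, so the two values show only that neither compound reached a number in this assay.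

Compound 3, `COc1ccc(C(=O)c2ccn(-c3ccc4c(c3)B(O)OC4)c2)cc1`, has not yet been measured. Its difference from compound 2 is 4-methoxyphenyl in place of 2-chlorophenyl on a carbonyl carbon. Given that compound 2 stands at the limit of > 10 ug/mL in this assay, at which 2 of the 2 values shown sit, the step that the limit leaves unreadable from compound 2 to compound 3 is expected to stay within the usual scatter, in no settled direction. Compound 3 is accordingly estimated at 15 ug/mL, with a range from 7 ug/mL to 40 ug/mL, and most likely the assay will again report only a limit for it.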

Compound 3, half-maximal inhibitory concentration: > 10 ug/mL
Compound 3: no number, only a limit; the forecaster's own chance of this, stated with the estimate: 80%; the middle value does not contradict the limit.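

Compound 2 and compound 3 both return only a limit of the assay in this assay, so no step can be read between them. The compounds shown leave open whether 4-methoxyphenyl in place of 2-chlorophenyl on a carbonyl carbon changes cytotoxicity at all, and at what concentration any of them would reach half-maximal inhibition.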